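The compounds below may be only part of what the source reports. "The series", "measured", "known", "first", "only" and "open" are said of these compounds alone.

Measured in a functional assay on A-375 cells (Homo sapiens) for cytotoxicity, read by CCK-8 assay, with a stated time of 24 h; a lower number here means a stronger inhibitor, a higher number a weaker inhibitor:
- compound 1 `COc1ccccc1Oc1c(N)nc(-c2cccc(C)c2)nc1Cl`: 65300 nM
- compound 2 `COc1ccccc1Oc1c(N)nc(-c2ccccc2)nc1OCCO`: > 80000 nM (a limit of the assay)
- compound 3 `COc1ccccc1Oc1c(N)nc(Cc2ccccc2)nc1OCCO`: 200 nM

Compound 3 stands lowest in this assay at 200 nM, well beyond the scatter from the nearest number, that of compound 1 at 65300 nM. The next compound to be tested is compound 4 `COc1ccccc1Oc1c(N)nc(-c2cccc(C)c2)nc1OCCO`, which has 3-methylphenyl in place of benzyl on an aromatic carbon, between two ring nitrogen atoms: 3-methylphenyl in place of benzyl on an aromatic carbon.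

Going by the values given here, one measured step bears on this change: an at least 400-fold lower number from compound 2 to compound 3 (2.60 log units; beyond the scatter), which is large and beyond the scatter, with benzyl in place of phenyl. The change to compound 4 removes that same benzyl in favour of a ring-bearing group without the connecting carbon, so most of that gain is expected to be lost. Compound 1 also carries 3-methylphenyl, though it differs elsewhere, and its number of 65300 nM points the same way.

A large move to a higher number is therefore expected, estimated as a 200-fold higher number from compound 3 to compound 4 (2.30 log units; beyond the scatter). Compound 4 is estimated at 40000 nM, with an expected range of 6000 nM to 100000 nM.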

Compound 4, half-maximal inhibitory concentration: 1380 nM
For compound 4 the middle estimate is 29-fold (1.46 log units) above the measured one; measured number below the stated range.
By their numbers in this assay, from the lowest: compound 3; then compound 4; then compound 1. At a limit, above all of these: compound 2.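

In this assay the carbon between two ring nitrogen atoms does not need the connecting carbon of benzyl for a low number: 3-methylphenyl in place of benzyl gives only a modest step, a 6.9-fold higher number from compound 3 to compound 4 (0.84 log units; beyond the scatter) and so keeps most of the potency. Methyl in place of hydrogen on the phenyl ring accounts for a large change, an at least 57-fold lower number from compound 2 to compound 4 (1.76 log units; beyond the scatter) but this step starts from the limit held by compound 2 and fixes only a bound: the limit of > 80000 nM in this assay, at which 1 of the 4 values shown sits.

With 3-methylphenyl kept, 2-hydroxyethoxy in place of chloro also gives a large step, a 47-fold lower number from compound 1 to compound 4 (1.68 log units; beyond the scatter) so the number of compound 4 depends on both places.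

Still open, on these data alone, is whether 3-methylbenzyl would add the gains of benzyl and methyl. Also open, as far as these compounds go, is whether 2-aminoethoxy or the longer 3-hydroxypropoxy chain would hold the number reached with 2-hydroxyethoxy.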